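Replacing a Terminal Sulfonamide with an Amine on a Shared Core

The source may hold more compounds than are shown below. What is called first, only, known or untested is meant among the compounds shown, and "the series" means these compounds.

Measured so far:
- compound 1, `CC(C)(C)c1ccc(C(=O)N2CCC3(CC2)C(=O)N(CC(=O)NCCCCO)CN3c2ccccc2)cc1`, 19200 nM
- compound 2, `CC(C)(C)c1ccc(C(=O)N2CCC3(CC2)C(=O)N(CC(=O)NCCCNS(C)(=O)=O)CN3c2ccccc2)cc1`, 10400 nM

In an assay on HEK293 cells for displacement of a labelled ligand from NPC1-like intracellular cholesterol transporter 1 (Homo sapiens) (on this read-out higher numbers stand for weaker inhibition and lower numbers for stronger inhibition), compound 2 gives 10400 nM, the lowest of the two numbers seen, while compound 1 gives 19200 nM. Within the data shown here, the only measured step, a 1.8-fold lower number from compound 1 to compound 2 (0.27 log units; within the scatter), tells that swapping the end of the chain had no effect the assay can resolve, so the two compounds cannot be ranked against each other.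

Compound 3, `CC(C)(C)c1ccc(C(=O)N2CCC3(CC2)C(=O)N(CC(=O)NCCCCN)CN3c2ccccc2)cc1`, is not yet measured. It differs from compound 2 in one place: aminomethyl in place of methanesulfonamido on a saturated chain carbon, three bonds along the chain from an amide-type nitrogen.

The step from compound 1 to compound 2 bears on this change, since it also exchanged the end group on the same chain carbon, and it fell inside the usual scatter. Among the measured compounds shown here, with only that step as a guide, and with both measured numbers close together, there is no reason to expect compound 3 to move beyond the scatter in either direction in this assay.

Compound 3 is therefore expected to give about 11000 nM in this assay, with a range from 4000 nM to 30000 nM, which amounts to an estimated step of a 1.1-fold higher number from compound 2 to compound 3 (0.02 log units; within the scatter).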

Compound 3, half-maximal inhibitory concentration: 14500 nM
Beside the measured number, compound 3's estimate is 1.3-fold (0.12 log units) below it, within the range that was stated.
By their numbers in this assay, from the lowest: compounds 2, 3 and 1 (each within the scatter of the next).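

In this assay, the amine end now adds a second exchange at the end of this chain: aminomethyl in place of methanesulfonamido gives a 1.4-fold higher number from compound 2 to compound 3 (0.14 log units; within the scatter), and amino in place of hydroxy gives a 1.3-fold lower number from compound 1 to compound 3 (0.12 log units; within the scatter). Together with the earlier step, this places all three end groups, hydroxy, methanesulfonamido and amino, within the scatter of one another, even though the exchange from compound 2 to compound 3 swaps a group of 5 heavy atoms for one of 2 heavy atoms, so among these compounds the assay resolves no difference at this position. No measurement is available that could explain this lack of separation.

The compounds shown leave open whether any end group on this chain can move the number beyond the scatter, and a carboxylic acid or a longer chain would test that. They also share one core, so they cannot tell whether the same exchanges would remain within the scatter on a different core.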